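Indanyl attachment point on a propyl-linked arylpiperazine series

The source may hold more compounds than are shown below. What is called first, only, known or untested is meant among the compounds shown, and "the series" means these compounds.

Of the compounds shown here, three sharing the same aryl-piperazine core have been measured in an assay on isolated protein for binding affinity to 5-hydroxytryptamine receptor 1B (Rattus norvegicus); a higher number here means a weaker inhibitor, a lower number a stronger inhibitor. Compound 1 `c1ccc2c(c1)CC(CCCN1CCN(c3cccc4c3OCCO4)CC1)C2` gives 1860 nM in this assay, the highest of the three numbers. Compound 2 `Clc1cccc2c1CC2CCN1CCN(c2cccc3c2OCCO3)CC1` gives 708 nM, and compound 3 `c1ccc2c(c1)CC2CN1CCN(c2cccc3c2OCCO3)CC1` gives 214 nM; both gaps to compound 1 lie beyond the usual scatter, so compound 1 is the weakest binder of the measured set. Among the compounds with values here, no pair among the measured compounds differs in a single place, so no step within the set can be read off directly.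

Compound 4 `c1ccc2c(c1)CCC2CCCN1CCN(c2cccc3c2OCCO3)CC1` is the next compound to be measured in this assay. Its change from compound 1 is 2,3-dihydro-1H-inden-1-yl in place of 2,3-dihydro-1H-inden-2-yl on a saturated chain carbon, three bonds along the chain from an amine nitrogen in a ring. The same atoms are present, joined differently, and nothing in the measured set speaks to this particular change.

Within the data shown here, with no comparable step on record, the expectation for the move from compound 1 to compound 4 is a step of a 1.2-fold lower number from compound 1 to compound 4 (0.09 log units; within the scatter), which is not expected to exceed the scatter in either direction. Compound 4 is therefore estimated at 1500 nM in this assay, with a range of 500 nM to 5000 nM.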

Compound 4, inhibition constant: 204 nM
The estimate for compound 4 lay 7.4-fold (0.87 log units) above the measured number; the whole stated range lies above it.
By their numbers in this assay, from the lowest: compounds 4 and 3 (each within the scatter of the next); then compound 2; then compound 1.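

In this assay, within the data shown here, 2,3-dihydro-1H-inden-1-yl in place of 2,3-dihydro-1H-inden-2-yl on a saturated chain carbon, three bonds along the chain from an amine nitrogen in a ring, gives a 9.1-fold lower number from compound 1 to compound 4 (0.96 log units; beyond the scatter), the first single-place step and one that lies beyond the scatter. The two groups match in atoms, ring counts and hydrogen-bond donor and acceptor counts, so the step shows that at this position, the way the group is joined to the chain is enough on its own to shift the number. No measured evidence on hand bears on what lies behind the step.

As far as these compounds go, it remains open whether the same change gives a step of similar size on a shorter or longer chain; compound 2 and compound 3 differ from compound 4 in more than one place, so they offer no readable step on this. Also open, from the compounds shown here alone, is how the number would respond to a methoxy or hydroxyl group on the 2,3-dihydro-1H-inden-1-yl group of compound 4.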